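The source may report more compounds than this note shows. Statements on the series, on what has been measured and on what is new or still open speak of the compounds shown alone.

Compound 3 `O=C(/C=C/C=C/c1ccc(OC2CCCC2)cc1)N1CCCCC1` is the second highest of the three compounds measured in an assay for inhibition of Polyunsaturated fatty acid 5-lipoxygenase (Homo sapiens), read by spectrophotometry, tested at 20 uM (a higher number here means more inhibition at the concentration tested (going by the name of the read-out), a lower number less inhibition), where compound 3 gives 16.1%. Its nearest neighbour is compound 2 `CN(C)c1ccc(/C=C/C=C/C(=O)N2CCCCC2)cc1`, which in this assay gives 13.4%, within the scatter of compound 3; furthest from it is compound 1 `COc1ccc(/C=C/C=C/C(=O)N2CCCCC2)c(OC)c1OC`, which gives 36%, beyond the scatter and higher. For the measured compounds named here, the only measured step that touches the same position is a number 2.7 percentage points higher from compound 2 to compound 3 (within the scatter), a swap of one group for another on the aromatic carbon that stays within the scatter. Compound 4 `O=C(/C=C/C=C/c1ccccc1)N1CCCCC1` follows from compound 3 by hydrogen in place of cyclopentyloxy on an aromatic carbon. Going by the values given here, no measured step removes this group outright, so the bearing of the measured step is indirect: an exchange at this aromatic carbon left the number within the scatter, and the higher value of compound 1 belongs to a differently substituted ring with no step to compound 3. The expected step is therefore a number 2.1 percentage points lower from compound 3 to compound 4 (within the scatter), none beyond the scatter, with a wide range given the thin evidence. Compound 4 is estimated at 14%, between 4% and 28%.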

Compound 4, a percentage reported as inhibition, at one concentration (the size of the read-out at that concentration, not a potency): 36.3%
Beside the measured number, compound 4's estimate is 22.3 percentage points below it; the measured number lies above the stated range.
By their numbers in this assay, from the lowest: compounds 2 and 3 (each within the scatter of the next); then compounds 1 and 4 (each within the scatter of the next).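

Hydrogen on this aromatic carbon, para to a large group, separates clearly from both substituted compounds in this assay: hydrogen in place of cyclopentyloxy gives a number 20.2 percentage points higher from compound 3 to compound 4 (beyond the scatter), and hydrogen in place of dimethylamino gives a number 22.9 percentage points higher from compound 2 to compound 4 (beyond the scatter). The earlier exchange of one group for the other, a number 2.7 percentage points higher from compound 2 to compound 3 (within the scatter), could not show this, since it compared two substituted compounds and neither had hydrogen at this position. Nothing measured here explains the size of these two steps.

Still open, as far as these compounds go, is whether the lower numbers of compound 2 and compound 3 extend to other groups at this position, such as a methoxy group or a fluorine atom. Also open, from the compounds shown here alone, is whether the same steps hold when the piperidine amide is replaced by a morpholine amide.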